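The source may report more compounds than this note shows. Statements on the series, on what has been measured and on what is new or still open speak of the compounds shown alone.

Compound 1 `COc1ccc2nc(C)cc(OCC(=O)Nc3cccc(C)c3)c2c1`: 4.83
Compound 2 `COc1ccc2nc(C)cc(OCC(=O)Nc3ccc(Cl)cc3Cl)c2c1`: 6.4
Compound 3 `COc1ccc2nc(C)cc(OCC(=O)Nc3ccc(Cl)c(OC)c3)c2c1`: 5.09

In a physicochemical assay for lipophilicity, read by HPLC, in phosphate buffer, measured as chromatographic lipophilicity, at pH 7.4 (on this read-out higher numbers stand for higher lipophilicity and lower numbers for lower lipophilicity), compound 3 stands second highest of the three numbers. Its nearest neighbour is compound 1, with the step of a number 0.26 log units higher from compound 1 to compound 3 (within the scatter); its furthest is compound 2, with the step of a number 1.31 log units lower from compound 2 to compound 3 (beyond the scatter). The only large move in the set is a number 1.57 log units higher from compound 1 to compound 2 (beyond the scatter), a swap between two carbon-only rings on the amide-type nitrogen.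

Compound 4 `COc1ccc2nc(C)cc(OCC(=O)Nc3nccs3)c2c1` has not yet been measured in this assay. It differs from compound 3 in one place: 1,3-thiazol-2-yl in place of 4-chloro-3-methoxyphenyl on an amide-type nitrogen. Within the data shown here, no measured step replaces the carbon-only ring with a five-membered ring bearing two hetero atoms, so none bears directly on this change; the measured steps only show that swaps on the amide-type nitrogen can move this assay by more than the scatter. Since the entering group is smaller and carries more acceptors, a downward step beyond the scatter is expected, a number 1.49 log units lower from compound 3 to compound 4 (beyond the scatter). Compound 4 is therefore estimated at 3.6, with a range from 3 to 4.3.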

Compound 4, distribution coefficient: 3.2
Compound 4: middle estimate off by 0.40 log units, on the high side; measured number inside the range.
By their numbers in this assay, from the lowest: compound 4; then compounds 1 and 3 (each within the scatter of the next); then compound 2.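

In this assay, the amide-type nitrogen now carries a five-membered aromatic ring with 2 hetero atoms rather than a six-membered ring of carbon only, and the number falls whichever ring leaves (a number 1.89 log units lower from compound 3 to compound 4 (beyond the scatter); a number 1.63 log units lower from compound 1 to compound 4 (beyond the scatter); a number 3.20 log units lower from compound 2 to compound 4 (beyond the scatter)). Compound 4 is thus the lowest of the four, with all its steps beyond the scatter, so this position spans a wider range than the earlier swaps showed. Nothing at hand explains the size of these steps.

Going by these compounds, what remains open is whether the fall follows the hetero atoms of the 1,3-thiazol-2-yl group or its fewer heavy atoms. An unsubstituted phenyl or a pyridin-2-yl on the same nitrogen would bear on that question.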